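This account rests on a few compounds, and the source may have more. Where it says the series, first, only, none or still open, it means among the compounds named here.

Measured so far:
- compound 1 `O=C(/C=C/c1ccc(OCc2cn(Cc3ccccc3)nn2)cc1)c1ccc(Br)cc1`: 34%
- compound 2 `O=C(/C=C/c1ccc(OCc2cn(Cc3ccccc3Br)nn2)cc1)c1ccc(Br)cc1`: 44%
- compound 3 `O=C(/C=C/c1ccc(OCc2cn(Cc3cccc(F)c3)nn2)cc1)c1ccc(Br)cc1`: 37%

In a functional assay on A549 cells (Homo sapiens) for inhibition, read by MTT assay, with a stated time of 48 h, tested at 10 uM (a lower number here means less inhibition of growth, a higher number more inhibition of growth at the concentration tested), compound 2 stands at the top of the three numbers, yet the step of a number 10 percentage points higher from compound 1 to compound 2 (within the scatter) and the step of a number 7 percentage points lower from compound 2 to compound 3 (within the scatter) both sit within the scatter, so the three compounds are not separated. Compound 4 `O=C(/C=C/c1ccc(OCc2cn(Cc3ccc(F)cc3)nn2)cc1)c1ccc(Br)cc1` differs from compound 2 by 4-fluorophenyl in place of 2-bromophenyl on a saturated chain carbon bound to an aromatic nitrogen. Among the measured compounds shown here, two measured steps bear on this: a number 3 percentage points higher from compound 1 to compound 3 (within the scatter), fluoro in place of hydrogen, and a number 7 percentage points lower from compound 2 to compound 3 (within the scatter), a fluorophenyl in place of the 2-bromophenyl at the same place; neither leaves the scatter. For the measured compounds named here, no measured pair shows the 4-fluorophenyl itself. The expectation is therefore no step beyond the scatter, a number 6 percentage points lower from compound 2 to compound 4 (within the scatter). Compound 4 is estimated at 38%, within 27% to 49%.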

Compound 4, percent growth inhibition at one concentration: 43%
Compound 4: the middle estimate sits 5 percentage points below what was measured; the measured number falls inside the stated range.
By their numbers in this assay, from the lowest: compounds 1, 3, 4 and 2 (each within the scatter of the next).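

In this assay, the place on a saturated chain carbon bound to an aromatic nitrogen tolerates a change of both halogen and ring position without separating the compounds: 4-fluorophenyl for 2-bromophenyl gives a number 1 percentage points lower from compound 2 to compound 4 (within the scatter), and 4-fluorophenyl for 3-fluorophenyl gives a number 6 percentage points higher from compound 3 to compound 4 (within the scatter). Against the ring without a halogen the picture is the same, with a number 9 percentage points higher from compound 1 to compound 4 (within the scatter). No supporting data bear on this result.

The compounds shown carry only hydrogen, fluoro or bromo on this phenyl ring. As far as these compounds go, whether an amine or a carboxylic acid on that ring, or a longer chain in place of the benzyl carbon, would give a step beyond the scatter remains open.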